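The compounds below may be only part of what the source reports. "The series", "measured", "known", "first", "only" and "open" are said of these compounds alone.

Measured so far:
compound 1, `NC(=O)c1ccc2c(c1)CCOC2CCN1CC=C(c2[nH]nc3cc(F)ccc23)CC1`, 24 nM in an assay on cells for binding affinity to 5-hydroxytryptamine receptor 1D (Homo sapiens), read by radioligand binding; a higher number here means a weaker inhibitor, a lower number a stronger inhibitor
compound 2, `NC(=O)c1ccc2c(c1)CCOC2CCN1CC=C(c2c[nH]c3cc(Cl)ccc23)CC1`, 145 nM in this assay

For the measured compounds named here, compound 2 has the highest number of the two, and the only step touching it is a 6.0-fold higher number from compound 1 to compound 2 (0.78 log units; beyond the scatter). Compound 3, `NC(=O)c1ccc2c(c1)CCOC2CCN1CC=C(c2c[nH]c3ccc(F)cc23)CC1`, has not yet been measured. It differs from compound 2 by 5-fluoro-1H-indol-3-yl in place of 6-chloro-1H-indol-3-yl on a double-bonded ring carbon. Going by the values given here, no measured step changes only the halogen, or only its position, on an indolyl group; the one step available swaps both the ring type and the halogen at once, so it bears on this change only loosely. Since compound 1, which carries a fluorine, gives 24 nM, the return to a fluorine in compound 3 is expected to bring a somewhat lower number, though the ring type stays that of compound 2. The step from compound 2 to compound 3 is therefore estimated as a 2.4-fold lower number from compound 2 to compound 3 (0.38 log units; beyond the scatter). Compound 3 is expected to give about 60 nM, with a likely range from 20 nM to 180 nM.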

Compound 3, inhibition constant: 130 nM
Compound 3: the middle estimate sits 2.2-fold (0.34 log units) below what was measured; the range from low to high includes it.
By their numbers in this assay, from the lowest: compound 1; then compounds 3 and 2 (each within the scatter of the next).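

In this assay, 5-fluoro-1H-indol-3-yl in place of 6-chloro-1H-indol-3-yl gives a step (a 1.1-fold lower number from compound 2 to compound 3 (0.05 log units; within the scatter)), so on this double-bonded ring carbon the two indolyl groups cannot be told apart, although both the halogen and its position differ. Compound 1 also remains separate from the fluorinated indolyl compound (a 5.4-fold higher number from compound 1 to compound 3 (0.73 log units; beyond the scatter)), so among these compounds a fluorine alone does not go with the lower number: compound 3 carries one too, yet only compound 1, with 6-fluoro-2H-indazol-3-yl, stands apart. Nothing measured here gives a reason for either step.

Open, going by these compounds, is whether a plain indol-3-yl without any halogen, or one carrying a methoxy group, would differ from these two indolyl groups. Also open, on these data alone, is how 6-fluoro-1H-indol-3-yl would compare, since it would separate the ring type from the halogen in the step from compound 1.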